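A few compounds are considered here, and "the series" means these few. Any claim that something is new, unique, unknown or untested is made for them only; others in the source may bear on it.

In an ADME assay on HepG2 cells (Homo sapiens) for cytotoxicity, read by MTT assay, with a stated time of 48 h (a higher number here means that more compound is tolerated, a lower number that less compound is tolerated), compound 2 `C#CCN(c1nc(-c2ccc(C)cc2)no1)C1CCCCC1` gives 91.9 ug/mL. Compound 3 `COc1ccc(-c2noc(N(Cc3cn(C[C@H](CO[C@@H]4C=C[C@H](OC(C)=O)[C@@H](COC(C)=O)O4)OC(C)=O)nn3)C3CCCCC3)n2)cc1` gives 141 ug/mL, within the scatter of compound 2, while compound 1 `CC(=O)OC[C@H]1O[C@H](OC[C@@H](Cn2cc(CN(c3nc(-c4ccc(F)cc4)no3)C3CCCCC3)nn2)OC(C)=O)C=C[C@@H]1OC(C)=O` gives a clearly lower 28.8 ug/mL. Compound 4 `C#CCN(c1nc(-c2ccc([N+](=O)[O-])cc2)no1)C1CCCCC1` has nitro in place of methyl on an aromatic carbon, para to a large group (nitro in place of methyl on an aromatic carbon). Within the data shown here, only one measured step bears on this, and only loosely: a 4.9-fold higher number from compound 1 to compound 3 (0.69 log units; beyond the scatter), a modest change with methoxy in place of fluoro on an aromatic carbon. That swap involves other groups on a larger structure, so it shows that such a swap can shift the number, but it does not fix a direction here. A change within the scatter is therefore expected, with a slight lean downward. The estimated step is a 1.3-fold lower number from compound 2 to compound 4 (0.12 log units; within the scatter). For compound 4, the expected value is 70 ug/mL, with an estimated range of 25 ug/mL to 190 ug/mL.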

Compound 4, half-maximal cytotoxic concentration: 43.7 ug/mL
Compound 4: the middle estimate sits 1.6-fold (0.20 log units) above what was measured, and the stated range covers the measured number.
By their numbers in this assay, from the lowest: compounds 1 and 4 (each within the scatter of the next); then compounds 2 and 3 (each within the scatter of the next).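

In this assay, nitro in place of methyl on this aromatic carbon, para to a large group, gives a 2.1-fold lower number from compound 2 to compound 4 (0.32 log units; beyond the scatter) and so a modest loss in the amount of compound tolerated. This is a direct comparison in one place on the smaller core, and it gives this swap a direction that the earlier step on a larger structure could not. Nothing measured here says what lies behind the change.

Going by these compounds, whether other groups on this carbon would lower the number as well remains open. An amine or a carboxylic acid at this place would test that.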